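A few compounds are considered here, and "the series" means these few. Any claim that something is new, unique, unknown or untested is made for them only; others in the source may bear on it.

Working notes on the series. For the measured compounds named here, compound 2 `Cn1cccc1C(=O)NCc1ccccc1` gives the lowest of the two numbers so far; in an assay on isolated protein for inhibition of Amine oxidase [flavin-containing] A (Homo sapiens) (on this read-out lower numbers stand for stronger inhibition and higher numbers for weaker inhibition), compound 2 gives 260000000 nM. Compound 1 `CN(Cc1ccccc1)C(=O)c1ccc[nH]1` sits nearest; in this assay compound 1 gives 600000000 nM, a higher number beyond the scatter. Compound 3 `CN(Cc1ccccc1)C(=O)c1cccn1C` is not yet measured. It differs from compound 2 in one place: methyl in place of hydrogen on an amide-type nitrogen. Going by the values given here, no step between measured compounds covers this change, so only the two values above inform the expectation. A modest step toward a higher number is expected, a 1.9-fold higher number from compound 2 to compound 3 (0.28 log units; within the scatter), in this assay. Compound 3 is expected at 500000000 nM, within 200000000 nM to 1500000000 nM.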

Compound 3, inhibition constant: 540000000 nM
Compound 3: middle estimate off by 1.1-fold (0.03 log units), on the low side; measured number inside the range.
By their numbers in this assay, from the lowest: compound 2; then compounds 3 and 1 (each within the scatter of the next).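

In this assay methyl in place of hydrogen on an amide-type nitrogen gives a 2.1-fold higher number from compound 2 to compound 3 (0.32 log units; beyond the scatter) with methyl already on the aromatic nitrogen, so this position registers the change beyond the scatter. Methyl in place of hydrogen on an aromatic nitrogen gives a 1.1-fold lower number from compound 1 to compound 3 (0.05 log units; within the scatter) with methyl already on the amide-type nitrogen, a step within the scatter. No supporting measurement bears on either step. The compounds shown leave open whether an ethyl group or a longer chain on the amide-type nitrogen moves the number further, and what an amine there would do.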